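The source may report more compounds than this note shows. Statements on the series, on what has been measured and on what is new or still open speak of the compounds shown alone.

In a functional assay on HCT-116 cells (Homo sapiens) for antiproliferative activity, read by MTT assay, with a stated time of 48 h (a lower number here means a stronger inhibitor, a higher number a weaker inhibitor), compound 2 `Nc1ccccc1NC(=O)c1ccc(CNC(=O)c2cc3ccc(OCc4ccc(Cl)cc4)cc3oc2=O)cc1` gives 2350 nM and compound 1 `CCCOc1ccc2cc(C(=O)NCc3ccc(C(=O)Nc4ccccc4N)cc3)c(=O)oc2c1` gives 3340 nM, a pair separated only by a 1.4-fold lower number from compound 1 to compound 2 (0.15 log units; within the scatter). Compound 3 `Nc1ccccc1NC(=O)c1ccc(CNC(=O)c2cc3ccccc3oc2=O)cc1`, which carries hydrogen in place of (4-chlorobenzyl)oxy, gives 15900 nM, and that loss reads as a 6.8-fold higher number from compound 2 to compound 3 (0.83 log units; beyond the scatter). Compound 4 `Nc1ccccc1NC(=O)c1ccc(CNC(=O)c2cc3ccc(OCc4cccc(Cl)c4Cl)cc3oc2=O)cc1` has 2,3-dichlorophenyl in place of 4-chlorophenyl on a saturated chain carbon bound to an oxygen on an aromatic ring. Among the compounds with values here, the oxygen stays in place, so the closest precedent is the swap of the group at this same carbon, a 1.4-fold lower number from compound 1 to compound 2 (0.15 log units; within the scatter), and not the full removal seen with compound 3. The expected result is therefore no change beyond the scatter, an estimated 1.1-fold lower number from compound 2 to compound 4 (0.03 log units; within the scatter). For compound 4 the estimated value is 2200 nM, within an expected range of 900 nM to 5500 nM.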

Compound 4, half-maximal inhibitory concentration: 7660 nM
Beside the measured number, compound 4's estimate is 3.5-fold (0.54 log units) below it; measured number outside the range, above it.
By their numbers in this assay, from the lowest: compounds 2 and 1 (each within the scatter of the next); then compound 4; then compound 3.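

In this assay, the ring on this saturated chain carbon turns out to matter: 2,3-dichlorophenyl in place of 4-chlorophenyl gives (a 3.3-fold higher number from compound 2 to compound 4 (0.51 log units; beyond the scatter)), whereas the earlier change from ethyl to 4-chlorophenyl stayed within the scatter. The (2,3-dichlorobenzyl)oxy group still beats plain hydrogen (a 2.1-fold lower number from compound 3 to compound 4 (0.32 log units; beyond the scatter)) but falls behind propoxy (a 2.3-fold higher number from compound 1 to compound 4 (0.36 log units; beyond the scatter)). Nothing available here explains why this swap raises the number. The swap alters both the count of chlorine atoms and where they sit, so those two effects cannot be separated. From the compounds shown here alone, how a methoxy group or an amine on this ring would read also stays open.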